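Benzyl amide versus fluoroanilide on the diazabicyclic pyridine core

A few compounds are considered here, and "the series" means these few. Any claim that something is new, unique, unknown or untested is made for them only; others in the source may bear on it.

The shared core carries an amide on the pyridine that bears the bridged diamine. Of the compounds shown here, three have numbers so far. Compound 1 `O=C(c1cncc(N2CC3CC(C2)N3)c1)N1CCc2ccccc2C1` gives 0.031 nM in an assay on membranes from Cerebral cortex for displacement of a labelled ligand from Neuronal acetylcholine receptor; alpha4/beta2 (Rattus norvegicus); a higher number here means a weaker inhibitor, a lower number a stronger inhibitor. Compound 2 `O=C(Nc1ccccc1F)c1cncc(N2CC3CC(C2)N3)c1` gives 0.315 nM in this assay. Compound 3 `COc1ccc(NC(=O)c2cncc(N3CC4CC(C3)N4)c2)cc1OC` gives 0.828 nM in this assay. Compound 2 stands second highest of the three: compound 3 lies at a higher number and the gap is beyond the scatter, while compound 1 lies at a much lower number, again beyond the scatter.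

Compound 4 `O=C(NCc1ccccc1)c1cncc(N2CC3CC(C2)N3)c1` differs from compound 2 by benzyl in place of 2-fluorophenyl on an amide-type nitrogen. The change replaces an aryl group directly on the amide nitrogen with a group that places the same ring one carbon further from it. Among the measured compounds there is no pair that differs by this move alone, so the expectation rests only on the spread seen across compounds 1, 2 and 3, all of which sit at very low numbers in this assay.

The step from compound 2 to compound 4 is expected to be small, a 1.1-fold lower number from compound 2 to compound 4 (0.05 log units; within the scatter), with no clear direction beyond the scatter. Compound 4 is therefore estimated at 0.28 nM, within a range from 0.07 nM to 1.1 nM.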

Compound 4, inhibition constant: 1.8 nM
Beside the measured number, compound 4's estimate is 6.4-fold (0.81 log units) below it; measured number outside the range, above it.
By their numbers in this assay, from the lowest: compound 1; then compound 2; then compound 3; then compound 4.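

Benzyl in place of 2-fluorophenyl on the amide nitrogen gives in this assay a 5.7-fold higher number from compound 2 to compound 4 (0.76 log units; beyond the scatter) and so provides the first single-place step in the series, showing that this position does not tolerate every change without loss of binding. The two groups have the same number of heavy atoms and the same six-membered aromatic ring of carbon only, yet the step runs toward the weaker inhibitor, so matching those counts does not keep the number low in this pair. The change removes the fluorine and adds a carbon in one move, and nothing shown here gives a measured reason for the step.

One pair cannot separate the contribution of the fluorine from that of the added carbon, and a plain phenyl on the same nitrogen would divide the step into those two parts. On these data alone, how the number responds to a longer chain, such as phenethyl, or to a benzyl carrying fluorine on its ring also remains open.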